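The source may hold more compounds than are shown below. What is called first, only, known or untested is meant among the compounds shown, and "the series" means these compounds.

Measured compounds:
Compound 1 `COc1ccc(C[C@H]2C(=O)N[C@@H](C)C(=O)N(C)[C@H]3Cc4ccc(cc4)Oc4cc(ccc4OC)C[C@@H](C(=O)N[C@H](C)C(=O)N[C@@H](CO)C(=O)N2C)N(C)C3=O)cc1` gives 14.1 nM in a functional assay on P388 cells (Mus musculus) for cytotoxicity; a lower number here means a stronger inhibitor, a higher number a weaker inhibitor.
Compound 2 `C=CC[C@@H]1NC(=O)[C@@H](C)NC(=O)[C@@H]2Cc3ccc(OC)c(c3)Oc3ccc(cc3)C[C@@H](C(=O)N2C)N(C)C(=O)[C@H](C)NC(=O)[C@H](Cc2ccc(OC)cc2)N(C)C1=O` gives 38.9 nM in this assay.

Compound 2 holds the higher of the two numbers in this assay; its nearest neighbour is compound 1, and the gap between them, a 2.8-fold higher number from compound 1 to compound 2 (0.44 log units; beyond the scatter), lies beyond the scatter. Compound 3 `COc1ccc(C[C@H]2C(=O)N[C@@H](C)C(=O)N(C)[C@H]3Cc4ccc(cc4)Oc4cc(ccc4OC)C[C@@H](C(=O)N[C@H](C)C(=O)N[C@@H](CC(=O)O)C(=O)N2C)N(C)C3=O)cc1` has not yet been measured. It differs from compound 2 in one place: carboxy in place of vinyl on a saturated chain carbon bound to a saturated ring carbon. Cut one bond further out, the change reads allyl to carboxymethyl.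

Among the measured compounds shown here, only one measured step touches this position, the exchange of hydroxy for vinyl on the same saturated chain carbon, which cost a 2.8-fold higher number from compound 1 to compound 2 (0.44 log units; beyond the scatter). For the measured compounds named here, no measured step shows carboxy at this site, so the direction of the new step is not fixed by the data; the single step available shows that this position does register changes of modest size. Compound 3 is therefore expected to sit within a modest distance of compound 2, with a 1.3-fold higher number from compound 2 to compound 3 (0.11 log units; within the scatter) as the estimated step. The estimate for compound 3 in this assay is 50 nM, within a range from 15 nM to 200 nM.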

Compound 3, half-maximal inhibitory concentration: 1200 nM
Estimate against measurement, compound 3: 24-fold (1.38 log units) below, outside the stated range (above it).
By their numbers in this assay, from the lowest: compound 1; then compound 2; then compound 3.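

In this assay, this position had so far shown only a modest response, with vinyl in place of hydroxy giving (a 2.8-fold higher number from compound 1 to compound 2 (0.44 log units; beyond the scatter)). Carboxy shows that the same saturated chain carbon can respond far more strongly, with large steps from both earlier groups: (a 31-fold higher number from compound 2 to compound 3 (1.49 log units; beyond the scatter)) from vinyl and (an 85-fold higher number from compound 1 to compound 3 (1.93 log units; beyond the scatter)) from hydroxy. Hydroxy and vinyl therefore do not mark the full range at this site, and the change from allyl to carboxymethyl is the largest departure seen here on the shared core, while the data offer no account of why this change weighs so heavily.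

The compounds shown leave open whether the large step belongs to carboxy alone or extends to other groups on this carbon, such as a methyl ester, a primary amide, an amine or a longer chain ending in a carboxylic acid. They also leave open whether carboxy would have a similar effect elsewhere on the core, since every step here concerns this one position and this one cell assay.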